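This account rests on a few compounds, and the source may have more. Where it says the series, first, only, none or still open, it means among the compounds named here.

Measured compounds:
compound 1 `O=C(NO)c1ccc(-c2cn([C@H]3C[C@@H](C(=O)O)N(Cc4ccccc4)C3)nn2)cc1`: < 10%
compound 2 `O=C(NO)c1cccc(-c2cn([C@H]3C[C@@H](CO)N(Cc4ccccc4)C3)nn2)c1`: < 10%
compound 3 `O=C(NO)c1cccc(-c2cn([C@H]3C[C@@H](C(=O)O)N(Cc4ccccc4)C3)nn2)c1`: 14%

Of the compounds shown here, three have been measured in an assay on Sf9 cells for inhibition of histone deacetylase 11 (Homo sapiens), read by fluorescence, tested at 0.5 uM; on this read-out higher numbers stand for more inhibition at the one concentration tested (going by the name of the read-out) and lower numbers for less inhibition. In this assay compound 1 gives < 10%, which is a limit of the assay rather than a number. In this assay compound 2 likewise gives < 10%, again only a limit. In this assay compound 3 gives 14%. The two steps that lead to compound 3 are a number at least 4 percentage points higher from compound 1 to compound 3 (that floor lies within the scatter) and a number at least 4 percentage points higher from compound 2 to compound 3 (that floor lies within the scatter); both are small, and their floor is set by the limit of < 10% in this assay, at which 2 of the 3 values shown sit.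

Compound 4 `O=C(NO)c1cccc(-c2cn([C@@H]3C[C@H](CO)N(Cc4ccccc4)C3)nn2)c1` is the partner of compound 2 in which (the two compounds have the same atoms and bonds and differ only in configuration as drawn: 2 of 2 stereo elements differ (all stereocentres are inverted: mirror images); a stereocentre at a saturated ring carbon is drawn S in compound 2 and R in compound 4; a stereocentre at a saturated ring carbon is drawn S in compound 2 and R in compound 4). For the measured compounds named here, no measured step compares two mirror images, so the two steps above bear on this change only by showing that compound 2 sits at a limit with little room below it. Compound 4 is therefore expected to show no step beyond the scatter, and the expected step is a step that the limit leaves unreadable from compound 2 to compound 4. The estimated value for compound 4 in this assay is 8%, expected to lie between 0% and 20%.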

Compound 4, a percentage reported as inhibition, at one concentration (the size of the read-out at that concentration, not a potency): < 10%
Compound 4: a limit, no number (the forecaster's own chance of this, stated with the estimate: 60%); the middle value does not contradict the limit.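

No step can be read from compound 2 to compound 4, a pair of mirror images, because each gives only a limit rather than a number: the limit of < 10% in this assay, at which 3 of the 4 values shown sit. The compounds shown leave open whether inverting both stereocentres changes the result in this assay at all.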